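Lengthening the Ether Chain of Compound 3

The compounds below may be only part of what the source reports. "The series", "measured", "known", "first", "only" and "open" are said of these compounds alone.

In a functional assay on DU-145 cells (Homo sapiens) for cytotoxicity, read by MTT assay, with a stated time of 48 h (a higher number here means a weaker inhibitor, a lower number a stronger inhibitor), the three measured compounds gave the following numbers:

Compound 1 `CCOC(=O)c1c(-c2c(Cl)c3ccccc3oc2=O)nn(-c2ccccc2)c1C(=O)OCC`: 48000 nM
Compound 2 `CCOC(=O)c1c(-c2cc3ccc(OC)cc3oc2=O)nn(-c2cccc(C)c2)c1C(=O)OCC`: 35000 nM
Compound 3 `CCOC(=O)c1c(-c2cc3ccc(OC)cc3oc2=O)nn(-c2cccc(Cl)c2)c1C(=O)OCC`: 38000 nM

Compound 3 stands second highest of these three numbers. Its nearest neighbour is compound 2, and its furthest is compound 1, yet both of those gaps lie within the scatter of this assay, so the three compounds cannot be ranked against one another on the values shown.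

Compound 4 `CCOC(=O)c1c(-c2cc3ccc(OCC=C(C)C)cc3oc2=O)nn(-c2cccc(Cl)c2)c1C(=O)OCC` is the next compound in line. It differs from compound 3 by 2-methylprop-1-en-1-yl in place of hydrogen on a saturated chain carbon bound to an oxygen on an aromatic ring. Among the measured compounds shown here, no measured step touches this position. For the measured compounds named here, the only step that has been measured, a 1.1-fold higher number from compound 2 to compound 3 (0.04 log units; within the scatter), concerns a substituent on a different aromatic carbon and stayed within the scatter, so it offers no guide to the present change, and there is nothing else to draw on.

Going by the values given here, with no precedent for the change and the series so far showing no movement beyond the scatter, the step of a 1.2-fold lower number from compound 3 to compound 4 (0.07 log units; within the scatter) is expected to stay within the scatter as well, in no particular direction. Compound 4 is therefore estimated to give 32000 nM in this assay, with a range from 10000 nM to 90000 nM.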

Compound 4, half-maximal inhibitory concentration: 139000 nM
For compound 4 the middle estimate is 4.3-fold (0.64 log units) below the measured one; the measured number lies above the stated range.
By their numbers in this assay, from the lowest: compounds 2, 3 and 1 (each within the scatter of the next); then compound 4.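

In this assay, among the compounds shown here, this is the first change to move the number beyond the scatter: the step (a 3.7-fold higher number from compound 3 to compound 4 (0.56 log units; beyond the scatter)) came with methoxy giving way to (3-methylbut-2-en-1-yl)oxy, and it went toward a weaker inhibitor. The earlier step (a 1.1-fold higher number from compound 2 to compound 3 (0.04 log units; within the scatter)), made on a different aromatic carbon, had stayed within the scatter, so this position, a saturated chain carbon bound to an oxygen on an aromatic ring, is the only place shown so far where a change registers in this cell assay. No available measurement bears on why the number rose with this change.

The compounds shown leave open whether the step follows the length of the chain or its double bond, a question that a plain ethoxy group or a saturated 3-methylbutoxy chain would help to separate. Also open, as far as these compounds go, is whether the same ether change would act alike with the methyl of compound 2 in place of the chloro, and how a chain ending in a hydroxy group or an amine would behave at this position.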